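Nitro-trifluoromethyl bicyclic series: cytotoxicity on Vero cells

A few compounds are considered here, and "the series" means these few. Any claim that something is new, unique, unknown or untested is made for them only; others in the source may bear on it.

Measured so far:
compound 1 `O=c1nc(NCc2ccc(F)cc2)oc2c([N+](=O)[O-])cc(C(F)(F)F)cc12`, > 64 ug/mL
compound 2 `O=c1nc(N2CCN(CC3CCCCC3)CC2)sc2c([N+](=O)[O-])cc(C(F)(F)F)cc12`, > 64 ug/mL
compound 3 `O=c1cc(N2CCN(CC3CCCCC3)CC2)oc2c([N+](=O)[O-])cc(C(F)(F)F)cc12`, 10.6 ug/mL

The read-out is an ADME assay on Vero cells (Chlorocebus sabaeus) for cytotoxicity, read by MTT assay, with a stated time of 48 h; a lower number here means a stronger inhibitor, a higher number a weaker inhibitor. Compound 1 gives > 64 ug/mL, which is a limit of the assay and not a number. Compound 2 likewise gives > 64 ug/mL, again a limit and not a number. Only compound 3 gives a number, 10.6 ug/mL. So compound 1 stands at the limit of > 64 ug/mL in this assay, at which 2 of the 3 values shown sit, together with one other compound, and no step between measured compounds that differ in one place is available to size the effect of any single change.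

The compound not yet measured is compound 4 `O=c1nc(NCC2CCCCC2)oc2c([N+](=O)[O-])cc(C(F)(F)F)cc12`. It differs from compound 1 by cyclohexyl in place of 4-fluorophenyl on a saturated chain carbon bound to a nitrogen on an aromatic ring. For the measured compounds named here, no measured pair shows what this exchange does in this assay; the shared core, the nitro group and the trifluoromethyl group are unchanged between the two.

With compound 1 at the limit of the assay, the step of a number no higher from compound 1 to compound 4 (the limit leaves the size open) is expected to be none beyond the scatter, and a repeat of the limit is the most likely outcome. Compound 4 is therefore estimated at 64 ug/mL, within a range from 30 ug/mL to 128 ug/mL.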

Compound 4, half-maximal inhibitory concentration: 29.7 ug/mL
Compound 4: middle estimate off by 2.2-fold (0.33 log units), on the high side; the whole stated range lies above it.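

In this assay, for the compounds shown here, cyclohexyl in place of 4-fluorophenyl on a saturated chain carbon bound to a nitrogen on an aromatic ring gives an at least 2.1-fold lower number from compound 1 to compound 4 (0.33 log units; beyond the scatter), the first step that can be read between compounds differing in one place. The group at this position therefore affects the read-out with the shared core, the nitro group and the trifluoromethyl group unchanged, and compound 4 at 29.7 ug/mL gives this substitution pattern a number rather than a limit. Compound 1, at > 64 ug/mL, stands at a limit of the assay and not a number, so the step has a lower bound but no upper one: the limit of > 64 ug/mL in this assay, at which 2 of the 4 values shown sit.

The exchange removes the aromatic ring and the fluorine together, so the compounds shown do not separate the two, and a plain benzyl group or a phenyl ring bearing chlorine would be needed to tell them apart. Also open, on these data alone, are the effect of a longer chain between the nitrogen and the cyclohexyl ring, of an amine on that ring, and whether the same exchange gives a similar step on other cores.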